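Replacing Phenyl with Thiazolyl on the Ring Amide Nitrogen

The source may hold more compounds than are shown below. What is called first, only, known or untested is meant among the compounds shown, and "the series" means these compounds.

Three compounds built on a shared core were measured in a functional assay on HOS-TE85 cells (Homo sapiens) for inhibition, read by CCK-8 assay, with a stated time of 72 h; on this read-out lower numbers stand for stronger inhibition and higher numbers for weaker inhibition. Compound 1 `COc1ccccc1N1C(=O)CSC1c1cc(F)cc(C(=O)NCCCCc2ccccc2)c1` gives 40.9 nM in this assay. Compound 2 `O=C(NCCCCc1ccccc1)c1cccc(C2SCC(=O)N2c2ccccc2)c1` gives 15.9 nM in this assay, and compound 3 `COc1ccccc1N1C(=O)CSC1c1cccc(C(=O)NCCCCc2cccs2)c1` gives 46 nM in this assay. Compound 2 stands at the lowest number of the three. Its nearest neighbour is compound 1, and its gaps to compound 1 and to compound 3 both lie beyond the usual scatter, so compound 2 is the most potent of the measured set.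

Compound 4 `O=C(NCCCCc1ccccc1)c1cccc(C2SCC(=O)N2c2nccs2)c1` has not yet been measured in this assay. It differs from compound 2 in one place: 1,3-thiazol-2-yl in place of phenyl on an amide-type nitrogen in a ring. For the measured compounds named here, no measured pair in this set shows the effect of such a change, so there is no direct comparison to draw on.

Going by the values given here, with no measured step of this kind, the change is expected to produce at most a small move, most likely toward weaker inhibition, of a size within or only slightly beyond the scatter. Compound 4 is therefore estimated at 25 nM, with a range from 7 nM to 90 nM. This estimate implies a step of a 1.6-fold higher number from compound 2 to compound 4 (0.20 log units; within the scatter), which is expected to stay close to the scatter of repeated measurements.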

Compound 4, half-maximal inhibitory concentration: > 1000 nM
Compound 4: no number, only a limit; the forecaster's own chance of this, stated with the estimate: 5%; at least 40-fold (1.60 log units) between middle value and limit.
By their numbers in this assay, from the lowest: compound 2; then compounds 1 and 3 (each within the scatter of the next). At a limit, above all of these: compound 4.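

Compound 4 has no number in this assay, only a limit of the assay: the limit of > 1000 nM in this assay, at which 1 of the 4 values shown sits. On the amide-type nitrogen in a ring, 1,3-thiazol-2-yl in place of phenyl gives a large change (an at least 62-fold higher number from compound 2 to compound 4 (1.79 log units; beyond the scatter)), so this one exchange is enough to move the lowest number of the set up to that limit. The earlier compounds shown here all carried a six-membered aromatic ring of carbon only at this position, so they could not show that this place is so sensitive to the ring it bears, at least for this one pair.

This single pair changes ring size, the ring's hetero atoms and the count of hydrogen-bond acceptors together, and it cannot tell which of these differences matters, or why. The compounds shown leave open how a 2-pyridyl group, which keeps the six-membered ring and adds one nitrogen, or a 2-thienyl group, which keeps the five-membered ring and has sulfur as its only hetero atom, would read at this position.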